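This account rests on a few compounds, and the source may have more. Where it says the series, first, only, none or still open, it means among the compounds named here.

Measured compounds and their values:

compound 1, `O=C(/C=C/c1cn(-c2ccccc2)nc1-c1ccsc1)c1ccccc1`, 1900 nM
compound 2, `COc1cc(C(=O)/C=C/c2cn(-c3ccccc3)nc2-c2ccsc2)cc(OC)c1OC`, 4900 nM
compound 3, `COc1cc(OC)c(C(=O)/C=C/c2cn(-c3ccccc3)nc2-c2ccsc2)c(OC)c1`, 2700 nM

In a functional assay on MCF7 cells (Homo sapiens) for inhibition, read by sulforhodamine B assay, with a stated time of 72 h (a higher number here means a weaker inhibitor, a lower number a stronger inhibitor), compound 1 shows the lowest number of the three. Compound 3 sits within the scatter of compound 1, so no order between them can be claimed; compound 2 lies beyond the scatter, a weaker inhibitor than compound 1.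

Compound 4, `O=C(/C=C/c1cn(-c2ccccc2)nc1-c1cccnc1)c1ccccc1`, has not yet been measured. It differs from compound 1 in one place: pyridin-3-yl in place of thiophen-3-yl on an aromatic carbon. Within the data shown here, no measured pair here shows the effect of such a swap, so the expectation rests on compound 1 alone. A step of modest size is expected in this assay, most likely not far beyond the scatter, with a slight lean toward a weaker inhibitor. The estimate for compound 4 in this assay is 2500 nM, within 800 nM to 8000 nM, an expected step of a 1.3-fold higher number from compound 1 to compound 4 (0.12 log units; within the scatter).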

Compound 4, half-maximal inhibitory concentration: 4100 nM
Estimate against measurement, compound 4: 1.6-fold (0.21 log units) below; measured number inside the range.
By their numbers in this assay, from the lowest: compounds 1, 3, 4 and 2 (each within the scatter of the next, the first and the last beyond it).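

Placing pyridin-3-yl in place of thiophen-3-yl on this aromatic carbon gives, in this assay, a 2.2-fold higher number from compound 1 to compound 4 (0.33 log units; beyond the scatter). Among these compounds, as the only single-place change here, it shows that this position responds to the ring it carries: compound 4 is a modestly weaker inhibitor than compound 1. Nothing available explains why the step arises.

This one swap changes both ring size and hetero atom, so their shares cannot be separated. On these data alone, how furan-3-yl, a five-membered ring, or pyridin-4-yl, a six-membered ring, would behave at this position remains open.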